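The source may hold more compounds than are shown below. What is called first, only, known or untested is meant among the compounds shown, and "the series" means these compounds.

Of the compounds shown here, three have so far been measured in an ADME assay on HEK293 cells (Homo sapiens) for cytotoxicity, read by CellTiter-Glo and resazurin assay, with a stated time of 72 h; a lower number here means that less compound is needed, a higher number that more compound is needed for the effect. Compound 1 `COc1ccc(F)c(-c2ccc(C(=O)N(Cc3cccc(OCCCCCC(=O)O)c3)C(C)C)cc2)c1` reaches only the limit of the assay, > 26000 nM. Compound 2 `CCOC(=O)CCCCCOc1cccc(CN(C(=O)c2ccc(-c3ccc4ccccc4c3)cc2)C(C)C)c1` likewise returns only a limit in this assay, > 26000 nM. Compound 3 `CCOC(=O)CCCCCOc1ccc(CNC(C)C)cc1` is again reported only as a limit in this assay, > 26000 nM. None of the three values is thus a number; all of them sit at the limit of > 26000 nM in this assay, at which 3 of the 3 values shown sit, and compound 3 stands exactly where the other two stand, with no gap to either of them that the data could reveal.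

Compound 4 `CCOC(=O)CCCCCOc1ccc(C(O)O)cc1` has not yet been measured in this assay. It differs from compound 3 in one place: dihydroxymethyl in place of (isopropylamino)methyl on an aromatic carbon. Going by the values given here, no step between measured compounds is available to scale this change, and compounds 1, 2 and 3 show only that the limit is reached by each of them. The step from compound 3 to compound 4 in this assay is therefore expected to be none beyond the scatter, a number no higher from compound 3 to compound 4 (the limit leaves the size open). Compound 4 is accordingly estimated to return 26000 nM in this assay, within a range from 13000 nM to 52000 nM, most probably once more as a limit rather than a number.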

Compound 4, half-maximal effective concentration: > 27100 nM
Compound 4: no number, only a limit (the forecaster's own chance of this, stated with the estimate: 85%); at least 1.0-fold (0.01 log units) between middle value and limit.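

In this assay compound 3 is reported only as a limit, > 26000 nM. Compound 4 is likewise reported only as a limit, > 27100 nM. With a limit on both sides, no step can be read between compound 3 and compound 4. The compounds shown leave open whether dihydroxymethyl in place of (isopropylamino)methyl on an aromatic carbon shifts the value in this assay.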